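Chloro for fluoro on the acid of compound 2

The source may hold more compounds than are shown below. What is called first, only, known or untested is meant among the compounds shown, and "the series" means these compounds.

Measured so far in a functional assay on 786-0 cells (Homo sapiens) for inhibition, read by sulforhodamine B assay, with a stated time of 48 h; a higher number here means a weaker inhibitor of growth, a lower number a stronger inhibitor of growth
- compound 1 `CCOC(=O)c1nn(-c2ccccc2)c(-c2ccc(Cl)cc2)c1CNC(C)(C)C` gives 86700 nM; > 559000 nM (2 entries)
- compound 2 `CC(C)(C)NCc1c(C(=O)O)nn(-c2ccccc2)c1-c1ccc(F)cc1` gives > 680000 nM

Compound 2 stands only at > 680000 nM as a limit of the assay and not as a number, and a further entry for it gives no single number either. Compound 3 `CC(C)(C)NCc1c(C(=O)O)nn(-c2ccccc2)c1-c1ccc(Cl)cc1` keeps the rest of compound 2 and differs by chloro in place of fluoro on an aromatic carbon with chloro in place of fluoro on an aromatic carbon. For the measured compounds named here, no measured pair shows this exchange, and no step beyond the usual scatter is expected in this assay on this change alone. Compound 1 carries the same 4-chlorophenyl group and shows 86700 nM; > 559000 nM (2 entries) across its entries. The estimated step of an at least 1.3-fold lower number from compound 2 to compound 3 (0.13 log units; that floor lies within the scatter) is expected to stay within the scatter. Compound 3 is expected near 500000 nM in an estimated range of 100000 nM to 800000 nM in this assay for growth inhibition.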

Compound 3, concentration for 50% growth inhibition: > 652000 nM
Compound 3 gave a limit, no number; the forecaster's own chance of this, stated with the estimate: 65%; at least 1.3-fold (0.11 log units) between middle value and limit.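

In this assay compound 3 gives only a limit of the assay (> 652000 nM). Compound 2 also gives only a limit (> 680000 nM), so no step can be read between compound 2 and compound 3. The compounds shown leave open what 4-fluorophenyl to 4-chlorophenyl does to growth inhibition on the acid.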